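A few compounds are considered here, and "the series" means these few. Any claim that something is new, unique, unknown or untested is made for them only; others in the source may bear on it.

The study brings together four compounds built on one shared core. Compound 1 `C=CC(=O)N1C(CC(=O)OCCCC)c2cccc(C)c2S1(=O)=O` and compound 2 `CCCCOC(=O)CC1c2cccc(C)c2S(=O)(=O)N1C(=O)/C=C/c1cc(F)cc(Cl)c1` carry different groups on the ring nitrogen of that core; in an assay on HEK-Blue hNOD1 cells for antagonist activity at Nucleotide-binding oligomerization domain-containing protein 1 (Homo sapiens), read by reporter gene assay, with stated times of 3 h and 20 h (on this read-out lower numbers stand for stronger inhibition and higher numbers for weaker inhibition), compound 1 returns "not determined" (no result reported), and compound 2 returns "not determined" (no result reported), so neither yields a number. For the measured compounds named here, compound 3 `CCCCOC(=O)CC1c2cccc(C)c2S(=O)(=O)N1C(=O)c1ccc(C(F)(F)F)cc1` is the one member with a result: in this assay compound 3 gives 1310 nM, the only figure in the set. Going by the values given here, with no second measured compound beside it, compound 3 cannot be ranked against anything else here. Compound 4 `CCCCOC(=O)CC1c2c(F)ccc(C)c2S(=O)(=O)N1C(=O)c1ccc(C(F)(F)F)cc1` differs from compound 3 by one change: fluoro in place of hydrogen on an aromatic carbon. Among the compounds with values here, no measured pair in this study shows what such a change does on this core. A single added fluorine of this kind is expected to move the half-maximal inhibitory concentration only a little, most likely within the usual scatter, and the step is estimated at a 1.1-fold lower number from compound 3 to compound 4 (0.04 log units; within the scatter). Compound 4 is therefore expected to give about 1200 nM, with a likely range from 500 nM to 3000 nM.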

Compound 4, half-maximal inhibitory concentration: 5820 nM
For compound 4 the middle estimate is 4.9-fold (0.69 log units) below the measured one, outside the stated range (above it).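

In this assay the swap of fluoro for hydrogen on the aromatic carbon para to a methyl group gives a 4.4-fold higher number from compound 3 to compound 4 (0.65 log units; beyond the scatter) and so weakens inhibition by more than the scatter. For the compounds shown here, this is the only measured pair on the shared core, and it shows that this position responds to a change of a single heavy atom. Nothing available here explains the step.

The compounds shown leave open whether the weakening belongs to fluoro itself or would also follow from another group on the same carbon, such as chloro, methoxy or an amine. They also leave open whether the step would hold with a different group on the ring nitrogen, or with a carboxylic acid in place of the butyl ester.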